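Amine swap on the side chain: compound 3 expected

A few compounds are considered here, and "the series" means these few. Any claim that something is new, unique, unknown or untested is made for them only; others in the source may bear on it.

Measured so far:
- compound 1, `COc1cc2ccc(=O)oc2cc1OCC(O)CN1CCN(C)CC1`, gives 3.4% in a functional assay on HUVEC cells (Homo sapiens) for inhibition, read by MTT assay, with a stated time of 24 h, tested at 100 uM; a lower number here means less inhibition of growth, a higher number more inhibition of growth at the concentration tested
- compound 2, `COc1cc2ccc(=O)oc2cc1OCC(O)CNC(C)C`, gives 6.3% in this assay

Compound 2 stands alongside compound 1: the step of a number 2.9 percentage points higher from compound 1 to compound 2 (within the scatter) falls within the scatter, so neither stands apart. Compound 3, `CCN(CC)CC(O)COc1cc2oc(=O)ccc2cc1OC`, carries the change (diethylamino in place of isopropylamino on a saturated chain carbon, two bonds along the chain from an oxygen on a saturated carbon). Among the compounds with values here, the one measured step bears only loosely on it, yet it shows that exchanging the amine here moved the number little. The step of a number 1.3 percentage points lower from compound 2 to compound 3 (within the scatter) is therefore expected to stay within the scatter. Compound 3 is estimated at 5%, ranging from -5% to 15%.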

Compound 3, percent growth inhibition at one concentration: 0.3%
Estimate against measurement, compound 3: 4.7 percentage points above; measured number inside the range.
By their numbers in this assay, from the lowest: compounds 3, 1 and 2 (each within the scatter of the next).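

In this assay, a third amine at this place on the chain gives the same picture: a number 6 percentage points lower from compound 2 to compound 3 (within the scatter) and a number 3.1 percentage points lower from compound 1 to compound 3 (within the scatter) both stay within the scatter. Diethylamino has no hydrogen-bond donor whereas isopropylamino has one, and even this difference leaves the number within the scatter. Nothing measured here offers an explanation for the result. Still open, going by these compounds, is whether a morpholine or a carboxylic acid in place of these amines, or a longer chain carrying the amine, would move the number beyond the scatter.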